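The compounds below may be only part of what the source reports. "The series", "measured", "known", "first", "only" and "open" are said of these compounds alone.

Compound 1 `CC(C)c1ccc(-c2nc(SCc3cn(CC(=O)NC(=O)Nc4ccccn4)nn3)nc(Nc3ccc(F)cc3)c2C#N)cc1`: in a functional assay on MGC-803 cells (Homo sapiens) for inhibition, read by MTT assay, with a stated time of 72 h (on this read-out lower numbers stand for stronger inhibition and higher numbers for weaker inhibition), compound 1 gives 17500 nM.
Compound 3 `Cc1ccc(Nc2nc(SCc3cn(CC(=O)NC(=O)Nc4ccccn4)nn3)nc(-c3ccc(C(C)C)cc3)c2C#N)cc1`: compound 3 gives 3360 nM.
Compound 2 `CC(C)c1ccc(-c2nc(SCc3cn(CC(=O)NC(=O)Nc4ccccn4)nn3)nc(Nc3cccc(Cl)c3)c2C#N)cc1`: for compound 2 this assay reports only a limit, > 64000 nM.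

Compound 1 stands highest of the two numbers shown; its nearest neighbour is compound 3, reached by a 5.2-fold lower number from compound 1 to compound 3 (0.72 log units; beyond the scatter). Compound 2 sits at the limit, (the limit of > 64000 nM in this assay, at which 1 of the 3 values shown sits), so the step of an at least 3.6-fold higher number from compound 1 to compound 2 (0.56 log units; beyond the scatter) is known only as a lower bound.

Compound 4 `Cc1cccc(Nc2nc(SCc3cn(CC(=O)NC(=O)Nc4ccccn4)nn3)nc(-c3ccc(C(C)C)cc3)c2C#N)c1` has not yet been measured. It differs from compound 1 in one place: 3-methylphenyl in place of 4-fluorophenyl on a nitrogen on an aromatic ring. Among the measured compounds shown here, two measured steps bear on this change. The first, a 5.2-fold lower number from compound 1 to compound 3 (0.72 log units; beyond the scatter), shows that a methyl on the same ring lowered the number. The second, an at least 3.6-fold higher number from compound 1 to compound 2 (0.56 log units; beyond the scatter), shows that a substituent at the position now taken by the methyl raised it. The new ring combines the methyl of compound 3 with the position of compound 2, so the two steps pull in opposite directions, and the expected outcome is a step of no more than modest size either way, a 1.2-fold lower number from compound 1 to compound 4 (0.07 log units; within the scatter). Compound 4 is therefore estimated at 15000 nM in this assay, within a range from 5000 nM to 50000 nM.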

Compound 4, half-maximal inhibitory concentration: 25300 nM
Compound 4: middle estimate off by 1.7-fold (0.23 log units), on the low side; the range from low to high includes it.
By their numbers in this assay, from the lowest: compound 3; then compounds 1 and 4 (each within the scatter of the next). At a limit, above all of these: compound 2.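

With the methyl kept and only the group changed from 4-methylphenyl to 3-methylphenyl, this assay gives a 7.5-fold higher number from compound 3 to compound 4 (0.88 log units; beyond the scatter), so the lower number of compound 3 cannot be credited to a methyl on this ring in general. Against the 4-fluorophenyl group, the 3-methylphenyl group makes no readable difference: a 1.4-fold higher number from compound 1 to compound 4 (0.16 log units; within the scatter). Methyl in place of chloro on the same ring gives an at least 2.5-fold lower number from compound 2 to compound 4 (0.40 log units; beyond the scatter), a step known only as a lower bound, and compound 2 stands at a limit: the limit of > 64000 nM in this assay, at which 1 of the 4 values shown sits.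

The compounds shown leave open how 4-chlorophenyl or 3-fluorophenyl would read, so the identity of the substituent cannot yet be separated from its place on the ring. From the compounds shown here alone, whether a longer chain, as in 4-ethylphenyl, would give a lower number than compound 3 also remains open.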